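Replacing the dichlorinated aryl group on compound 1

The source may hold more compounds than are shown below. What is called first, only, known or untested is meant among the compounds shown, and "the series" means these compounds.

Compounds measured so far:
Compound 1, `Nc1ccccc1NC(=O)CCCNCC(=O)Nc1cc(Cl)ccc1Cl`: in a functional assay on U-251 cells (Homo sapiens) for inhibition, read by MTT assay, with a stated time of 2 days (on this read-out higher numbers stand for lower toxicity in this test and lower numbers for higher toxicity in this test), compound 1 gives > 100000 nM, which is a limit of the assay rather than a number.
Compound 2, `COc1ccc(NC(=O)CNc2ccc(C(=O)Nc3ccccc3N)cc2)cc1`: in this assay compound 2 gives > 100000 nM, again a limit of the assay.
Compound 3, `Nc1ccccc1NC(=O)c1ccc(NCC(=O)Nc2ccc([N+](=O)[O-])cc2)cc1`: in this assay compound 3 gives > 100000 nM, also a limit of the assay.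

Compound 1 therefore stands where every value shown stands, at the limit of > 100000 nM in this assay, at which 3 of the 3 values shown sit. None of the three compounds has a number that could be set against another, so no order among them can be read.

Compound 4, `Nc1ccccc1NC(=O)CCCNCC(=O)Nc1ccc(Cl)cc1`, is the compound still to be measured. It differs from compound 1 in one place: 4-chlorophenyl in place of 2,5-dichlorophenyl on an amide-type nitrogen.

Within the data shown here, the only step between measured compounds that differ in one place is a step that the two limits leave unreadable from compound 2 to compound 3, and its size cannot be read from the two limits. It concerns a different group on a different part of the molecule and does not bear on the change from compound 1 to compound 4. Among the measured compounds shown here, no measured step involves the group that leaves or the group that enters here.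

With every value at the limit, compound 4 is expected to stay there too, and the expected step that the limit leaves unreadable from compound 1 to compound 4 is none beyond the scatter. The estimate for compound 4 in this assay is 150000 nM, with a range from 50000 nM to 500000 nM.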

Compound 4, concentration lethal to 50% of the cells: > 100000 nM
Compound 4 ended at the assay's limit (the forecaster's own chance of this, stated with the estimate: 85%); the middle value lies beyond the limit too.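

Compound 1 and compound 4 both sit at a limit of this assay rather than at a number, so swapping 2,5-dichlorophenyl for 4-chlorophenyl gives no step that can be read: the limit of > 100000 nM in this assay, at which 4 of the 4 values shown sit.

The compounds shown leave open whether these two groups differ at all in this assay, and which change to the shared core would give a number instead of a limit.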